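Chloro for bromo on the aryl substituent of compound 2

The compounds below may be only part of what the source reports. "The series", "measured", "known", "first", "only" and "open" are said of these compounds alone.

Two compounds of this series have been run so far, and both carry the same core. Compound 1 `O=C1COc2ccc(-c3[nH]c(-c4ccc(C(F)(F)F)cc4)nc3-c3ccccc3)cc2N1` is one of them; in a functional assay on MV4-11 cells (Homo sapiens) for cytotoxicity, read by colorimetric assay and MTT assay, with a stated time of 3 days, tested at 1 uM (a lower number here means a stronger effect, a higher number a weaker effect of the compound at the concentration tested), compound 1 gives 111%. Compound 2 `O=C1COc2ccc(-c3nn(-c4ccc(Br)cc4)cc3-c3ccccc3)cc2N1` is the other; in this assay compound 2 gives 108%. The two numbers lie within the usual scatter of one another, so the data do not separate compound 2 from compound 1, and neither shows a meaningful effect at the concentration tested.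

Compound 3 `O=C1COc2ccc(-c3nn(-c4ccc(Cl)cc4)cc3-c3ccccc3)cc2N1` has not yet been measured. It differs from compound 2 in one place: chloro in place of bromo on an aromatic carbon. Among the compounds with values here, no measured pair shows what this change does here, so the expectation rests on the two numbers at hand. For compound 3 no step beyond the scatter is expected from compound 2, which gives 108% in this assay. The estimate for compound 3 is 108%, with a range from 97% to 119%. The expected step is no change at the digits printed from compound 2 to compound 3 (within the scatter).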

Compound 3, a percentage reported as activity, at one concentration (the size of the read-out at that concentration, not a potency): 108%
For compound 3 middle estimate and measured number coincide at the digits printed; measured number inside the range.
By their numbers in this assay, from the lowest: compounds 2, 3 and 1 (each within the scatter of the next).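

In this assay, within the data shown here, the change from 4-bromophenyl to 4-chlorophenyl gives no change at the digits printed from compound 2 to compound 3 (within the scatter), the first pair that differs in one place. At this position, para to a large group, chloro in place of bromo therefore brings out no effect at the concentration tested, and compound 3 does not separate from compound 2. The data at hand offer no account of this result, as nothing measured alongside the read-out bears on it.

Going by these compounds, the pair covers only these two substituents on the aromatic ring, so it remains open whether an amine, a carboxylic acid or a longer chain at the same place would move the read-out. On these data alone, it also remains open whether the same exchange would give the same result on the trifluoromethyl-bearing ring of compound 1.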